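This account rests on a few compounds, and the source may have more. Where it says the series, first, only, none or still open, it means among the compounds named here.

Measured so far:
- compound 1 `COc1cc(-c2nc3cc(/C=C4\SC(=O)NC4=O)ccc3[nH]2)cc(OC)c1OC`: 13600 nM
- compound 2 `COc1ccc(-c2nc3cc(/C=C4\SC(=O)NC4=O)ccc3[nH]2)cc1OC`: 21700 nM
- compound 3 `COc1ccc(-c2nc3cc(/C=C4\SC(=O)N(CC(=O)N5CCOCC5)C4=O)ccc3[nH]2)cc1OC`: > 50000 nM

Series notes. In an ADME assay on HEK-293T cells (Homo sapiens) for inhibition, read by MTT assay, with a stated time of 48 h (on this read-out lower numbers stand for stronger inhibition and higher numbers for weaker inhibition), compound 2 gives 21700 nM and compound 1 gives 13600 nM. Compound 3 reaches only a limit of the assay, > 50000 nM, which is the limit of > 50000 nM in this assay, at which 1 of the 3 values shown sits. The step of a 1.6-fold lower number from compound 2 to compound 1 (0.20 log units; within the scatter) corresponds to methoxy in place of hydrogen on an aromatic carbon. The step of an at least 2.3-fold higher number from compound 2 to compound 3 (0.36 log units; beyond the scatter) corresponds to ((morpholin-4-yl)carbonyl)methyl in place of hydrogen on an amide-type nitrogen in a ring; this is also how the core of compound 3 differs from the core of compound 2.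

Compound 4 `COc1cc(OC)c(-c2nc3cc(/C=C4\SC(=O)N(CC(=O)N5CCOCC5)C4=O)ccc3[nH]2)cc1OC` is not yet measured. It differs from compound 3 by methoxy in place of hydrogen on an aromatic carbon. This is the same kind of change as from compound 2 to compound 1, but the place is not the same: there the methoxy sits ortho to a methoxy group, meta to a large group and meta to a methoxy group; here it sits ortho to a large group, meta to a methoxy group and para to a methoxy group.

In this assay the step from compound 3 to compound 4 is expected to be about a step that the limit leaves unreadable from compound 3 to compound 4, resting on the earlier step of a 1.6-fold lower number from compound 2 to compound 1 (0.20 log units; within the scatter), which stayed within the scatter, and on compound 3 sitting at the limit > 50000 nM. Compound 4 is estimated at 60000 nM, between 25000 nM and 200000 nM, most likely again reported only as a limit.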

Compound 4, half-maximal inhibitory concentration: 35700 nM
Compound 4: the middle estimate sits 1.7-fold (0.23 log units) above what was measured; low and high end bracket the measured number.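

In this assay the added methoxy, which turns the 3,4-dimethoxyphenyl of compound 3 into the 2,4,5-trimethoxyphenyl of compound 4, goes with an at least 1.4-fold lower number from compound 3 to compound 4 (0.14 log units; that floor lies within the scatter). The value of compound 3, > 50000 nM, is a limit of the assay and not a number. The two steps show that the change on the second core sits no worse than the floor printed with it, but they do not show that its effect carries from one core to the other, and the methoxy also takes a different place on the ring in each case: the same change on two cores in this assay, a 1.6-fold lower number (0.20 log units; within the scatter) from compound 2 to compound 1 and an at least 1.4-fold lower number (0.14 log units; that floor lies within the scatter) from compound 3 to compound 4; the limit leaves it open whether they differ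

The compounds shown leave open how the step reads when the same methoxy takes the same place on both cores, which would separate the effect of place from that of core. Going by these compounds, also open in this assay is how the ((morpholin-4-yl)carbonyl)methyl group compares with a simple amine, a carboxylic acid or a longer chain on the amide-type nitrogen in the ring.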